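The compounds below may be only part of what the source reports. "The series", "measured", "known", "first", "only" and "open" are said of these compounds alone.

In a functional assay on HCC 2998 cells (Homo sapiens) for antiproliferative activity (a lower number here means a stronger inhibitor of growth, a higher number a weaker inhibitor of growth), compound 3 `COc1ccc(-c2nc3cc(F)ccc3s2)cc1F` gives 13700 nM, the highest of the two numbers obtained so far. Its nearest comparison is compound 2 `COc1ccc(-c2nc3cc(F)ccc3s2)cc1C`, which gives 540 nM. Compound 1 `Cc1cc(-c2nc3ccccc3s2)ccc1N` gives > 100000 nM, and this is a limit of the assay, not a number.

Compound 4 `COc1ccc(-c2nc3cc(F)ccc3s2)cc1Br` has yet to be measured, and it alters compound 3 in one place: bromo in place of fluoro on an aromatic carbon. This puts bromo in place of fluoro on an aromatic carbon, ortho to a methoxy group. Among the compounds with values here, only one measured step bears on that carbon: a 25-fold higher number from compound 2 to compound 3 (1.40 log units; beyond the scatter). This large step, fluoro in place of methyl, lies beyond the scatter and shows that this assay responds strongly to the group held there. Of the two groups tried at this carbon, fluoro gave the higher number. Within the data shown here, no bromo compound has been measured, and any forecast rests on that single step.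

A large step towards a lower number is expected, recovering much of the gap to compound 2 at 540 nM, though with wide uncertainty. The expected change is a 9.1-fold lower number from compound 3 to compound 4 (0.96 log units; beyond the scatter). Compound 4 is estimated at 1500 nM, within an expected range of 200 nM to 10000 nM.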

Compound 4, concentration for 50% growth inhibition: 3450 nM
Compound 4: the middle estimate sits 2.3-fold (0.36 log units) below what was measured; the measured number falls inside the stated range.
By their numbers in this assay, from the lowest: compound 2; then compound 4; then compound 3. At a limit, above all of these: compound 1.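

The earlier compounds shown here showed only that fluoro gave a higher number than methyl on this aromatic carbon, ortho to a methoxy group, and the bromo compound adds a third point at the same carbon. In this assay, replacing fluoro with bromo gives a 4.0-fold lower number from compound 3 to compound 4 (0.60 log units; beyond the scatter), so the loss seen with fluoro is not shared equally by every halogen tried here, and part of the gap to the methyl compound is recovered. Bromo still does not match methyl, with a 6.4-fold higher number from compound 2 to compound 4 (0.81 log units; beyond the scatter), so the three groups form a clear order at this carbon, from methyl through bromo to fluoro, with each step beyond the scatter.

The compounds shown leave open where chloro, ethyl, hydroxy, trifluoromethyl or an amine would fall in this order, and whether any group at this carbon would give a lower number than methyl. They also give no measurement that accounts for the order of these three groups, as the only further observation concerns the assay limit reached by a compound that differs from them in more than one place.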